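The source may hold more compounds than are shown below. What is called first, only, known or untested is meant among the compounds shown, and "the series" means these compounds.

In a functional assay on DU-145 cells (Homo sapiens) for inhibition, read by trypan blue exclusion, with a stated time of 72 h (on this read-out lower numbers stand for stronger inhibition and higher numbers for weaker inhibition), compound 1 (`Cc1ccc(S(=O)(=O)c2cc3cnc(Nc4ccc5cc[nH]c5c4)nc3n(C)c2=O)cc1`) gives 15000 nM, and compound 2 (`O=c1[nH]c2nc(Nc3ccc4[nH]ccc4c3)ncc2cc1S(=O)(=O)c1ccc(F)cc1F`) gives 15000 nM. Compound 2 therefore stands level with compound 1, within the scatter, and both are weak on this read-out. The two compounds differ in more than one place, so their values isolate no single structural change.

Compound 3 (`O=c1c(S(=O)(=O)c2ccc(F)cc2F)cc2cnc(Nc3ccc4[nH]ccc4c3)nc2n1C1CC1`) comes from compound 2 by cyclopropyl in place of hydrogen on an aromatic nitrogen. The rest of compound 2 is kept, including the (2,4-difluorophenyl)sulfonyl group. Going by the values given here, no measured pair shows this change alone. Compound 1, which carries a methyl on the corresponding nitrogen, gives 15000 nM, and this offers no sign of a large gain from substitution there. A modest move toward stronger inhibition in this assay is still expected, though it may not clear the scatter by much. The expected change is a 2.5-fold lower number from compound 2 to compound 3 (0.40 log units; beyond the scatter). For compound 3 the estimated value is 6000 nM, with an expected range of 1000 nM to 20000 nM.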

Compound 3, half-maximal inhibitory concentration: 500 nM
Compound 3: middle estimate off by 12-fold (1.08 log units), on the high side; measured number outside the range, below it.
By their numbers in this assay, from the lowest: compound 3; then compounds 1 and 2 (each within the scatter of the next).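

In this assay, going by these compounds alone, cyclopropyl in place of hydrogen on an aromatic nitrogen gives the first single-place step (a 30-fold lower number from compound 2 to compound 3 (1.48 log units; beyond the scatter)), and it is large, so this nitrogen is a position at which the read-out responds strongly to substitution. Because compound 3 keeps the (2,4-difluorophenyl)sulfonyl group and the rest of compound 2, the step belongs to this one change, which the equal values of compounds 1 and 2 could not show. No measured property accompanies the step, and the data offer no explanation for its size.

As far as these compounds go, whether the step needs the three-membered ring or only a carbon substituent on this nitrogen stays open: compound 1 carries a methyl there but differs from compound 3 in more than one place, so it gives no reading of that group, and ethyl, isopropyl or cyclobutyl on the same nitrogen would separate these cases. From the compounds shown here alone, it also stays open whether cyclopropyl gives a step of this size with a sulfonyl aryl group other than (2,4-difluorophenyl), such as the 4-methylphenyl of compound 1.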